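A few compounds are considered here, and "the series" means these few. Any claim that something is new, unique, unknown or untested is made for them only; others in the source may bear on it.

Measured in an ADME assay on a cell-free system (plasma, Rattus norvegicus) for metabolic stability, read by LC-MS, with a stated time of 60 min, tested at 100 uM; a higher number here means that more of the compound is left, a lower number that less of the compound is left:
- Compound 1 `Cc1c(OCCCCOc2ccc(C(=O)O)cc2F)ccc(C(=O)CC(C)C)c1O` gives 106%
- Compound 2 `Cc1c(OCCCCOc2ccc(C(=O)O)cc2Cl)ccc(C(=O)CC(C)C)c1O` gives 123%
- Compound 3 `Cc1ccc(C(=O)O)cc1OCCCCOc1ccc(C(=O)CC(C)C)c(O)c1C` gives 96%

Compound 3 sits within the scatter of compound 1 and clearly under compound 2. Compound 4 `Cc1cc(OCCCCOc2ccc(C(=O)CC(C)C)c(O)c2C)ccc1C(=O)O` has the same atoms joined differently: 4-carboxy-3-methylphenyl in place of 5-carboxy-2-methylphenyl on an oxygen on a saturated carbon, with 4-carboxy-3-methylphenyl in place of 5-carboxy-2-methylphenyl on an oxygen on a saturated carbon. The closest evidence is the exchange of this same group, a number 10 percentage points lower from compound 1 to compound 3 (within the scatter) and a number 27 percentage points lower from compound 2 to compound 3 (beyond the scatter), alongside chloro in place of fluoro, a number 17 percentage points higher from compound 1 to compound 2 (beyond the scatter). These steps are modest or smaller, and none isolates this change. No shift beyond the scatter is therefore expected in this assay, in either direction. The expected step is a number 4 percentage points higher from compound 3 to compound 4 (within the scatter). Compound 4 is estimated at 100%, with an expected range of 82% to 118%.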

Compound 4, percent of the compound remaining: 101%
Compound 4: middle estimate off by 1 percentage points, on the low side; the range from low to high includes it.
By their numbers in this assay, from the lowest: compounds 3, 4 and 1 (each within the scatter of the next); then compound 2.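

In this assay, 4-carboxy-3-methylphenyl in place of 5-carboxy-2-methylphenyl on an oxygen on a saturated carbon gives a number 5 percentage points higher from compound 3 to compound 4 (within the scatter) and so leaves the read-out unmoved by this rearrangement of the same atoms. Against the halogen-bearing groups the new group gives a number 5 percentage points lower from compound 1 to compound 4 (within the scatter) and a number 22 percentage points lower from compound 2 to compound 4 (beyond the scatter) and so sets only the chloro member apart. Nothing on hand accounts for these steps. Open, from the compounds shown here alone, is how a methoxy or trifluoromethyl in place of the methyl would read. Also open, going by these compounds, is whether a longer chain between the two oxygens would keep this picture.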